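Acid dissociation in a diamine series: distal aryl exchange

The source may hold more compounds than are shown below. What is called first, only, known or untested is meant among the compounds shown, and "the series" means these compounds.

Measured so far:
compound 1 `COc1cccc(CNCCCNc2ccnc3cc(-c4ccc(C(C)(C)C)cc4)ccc23)c1O` — 9.47
compound 2 `CC(C)(C)c1ccc(-c2ccc3c(NCCCNCc4ccco4)ccnc3c2)cc1` — 9.47
compound 3 `COc1ccc(-c2ccc3c(NCCCNCc4ccco4)ccnc3c2)cc1` — 9.47

In a physicochemical assay for acid dissociation, compound 1 stands level with compounds 2 and 3. Both recorded steps, no change at the digits printed from compound 1 to compound 2 (within the scatter) and no change at the digits printed from compound 2 to compound 3 (within the scatter), stay within the scatter.

Compound 4 `COc1cccc(CNCCCNc2ccnc3cc(Cc4ccc(C#N)cc4)ccc23)c1O` awaits measurement. It differs from compound 1 in one place: 4-cyanobenzyl in place of 4-(tert-butyl)phenyl on an aromatic carbon. The second recorded step bears on this most directly because no change at the digits printed from compound 2 to compound 3 (within the scatter) also exchanged the group on an aromatic carbon of the shared core; the first step, no change at the digits printed from compound 1 to compound 2 (within the scatter), changed the other end of the chain and was likewise flat. No step beyond the scatter is therefore expected in this assay for compound 4, the expected step being no change at the digits printed from compound 1 to compound 4 (within the scatter). Compound 4 is estimated at 9.47, within 9.1 to 9.8.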

Compound 4, acid dissociation constant: 9.47
The estimate for compound 4 equals the measured number at the digits printed; the range from low to high includes it.
By their numbers in this assay, from the lowest: compounds 1, 2, 3 and 4 (each within the scatter of the next).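

In this assay, replacing the whole group on this aromatic carbon of the shared core gives no change at the digits printed from compound 1 to compound 4 (within the scatter). The earlier step at this end of the molecule exchanged only a substituent, whereas this one also brings in a nitrile and a saturated carbon attached to the core, and the read-out still stays flat. No evidence is available on why this read-out stays flat.

On these data alone, whether an amine or a carboxylic acid on this aromatic carbon would move the number remains open. As far as these compounds go, the effect of a longer chain linking the two amine nitrogens also remains open.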